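The source may hold more compounds than are shown below. What is called first, only, known or untested is meant among the compounds shown, and "the series" means these compounds.

Working notes on the series. In a functional assay on ECa-109 cells (Homo sapiens) for cytotoxicity, read by MTT assay, with a stated time of 72 h (a higher number here means a weaker inhibitor, a lower number a stronger inhibitor), compound 1 `Cc1cc(Nc2ccc(Cl)cc2)nc(SCc2nc3ccccc3[nH]2)n1` gives 20400 nM. Compound 2 `Cc1cc(N2CCCCC2)nc(SCc2nc3ccccc3[nH]2)n1` returns only the limit > 100000 nM in this assay, a limit and not a number. Compound 3 `Cc1cc(N2CCNCC2)nc(SCc2nc3ccccc3[nH]2)n1` likewise returns only the limit > 100000 nM. Both an at least 4.9-fold higher number from compound 1 to compound 2 (0.69 log units; beyond the scatter) and an at least 4.9-fold higher number from compound 1 to compound 3 (0.69 log units; beyond the scatter) run from a read number up to the limit, while a step that the two limits leave unreadable from compound 2 to compound 3 cannot be sized because both of its values sit at the limit of > 100000 nM in this assay, at which 2 of the 3 values shown sit.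

Compound 4 `COc1ccccc1Nc1cc(C)nc(SCc2nc3ccccc3[nH]2)n1` is the next to measure. It differs from compound 2 in one place: (2-methoxyphenyl)amino in place of piperidin-1-yl on an aromatic carbon. Within the data shown here, the one measured step that bears on this is an at least 4.9-fold higher number from compound 1 to compound 2 (0.69 log units; beyond the scatter), which runs the opposite way, from an arylamino group to piperidin-1-yl. Compound 4 restores an arylamino group, so the number is expected to fall back from the limit toward the reading of compound 1, the size unreadable from the limit itself. The estimate for compound 4 is 25000 nM, within 6000 nM to 100000 nM. That estimate means an expected step of an at least 4.0-fold lower number from compound 2 to compound 4 (0.60 log units; beyond the scatter).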

Compound 4, half-maximal inhibitory concentration: 34400 nM
Compound 4: the middle estimate sits 1.4-fold (0.14 log units) below what was measured, and the stated range covers the measured number.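

In this assay, the return of an arylamino group on this aromatic carbon brings the reading back from the limit, with an at least 2.9-fold lower number from compound 2 to compound 4 (0.46 log units; beyond the scatter) and an at least 2.9-fold lower number from compound 3 to compound 4 (0.46 log units; beyond the scatter). The aryl group itself can change without a readable effect, since a 1.7-fold higher number from compound 1 to compound 4 (0.23 log units; within the scatter), so 2-methoxyphenyl and 4-chlorophenyl are not told apart here. The full size of the first two steps stays unread because compound 2 and compound 3 carry limits and not numbers: the limit of > 100000 nM in this assay, at which 2 of the 4 values shown sit.

Going by these compounds, compound 1 and compound 4 both carry an aromatic ring on an amino nitrogen, and which part of that group goes with a readable number stays open. A benzylamino or a methyl(phenyl)amino group on this carbon would bear on that question.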